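The compounds below may be only part of what the source reports. "The series", "measured", "known", "first", "only" and "open" are said of these compounds alone.

Notes on the series. Compound 1 `O=C(NC1CCCCC1)c1cc2ccccc2oc1=O` carries the shared core with a cyclohexyl on the amide-type nitrogen. Going by the values given here, in an in vitro assay on BTI-TN-5B1-4 cells for inhibition of Amine oxidase [flavin-containing] B (Homo sapiens), read by fluorescence (on this read-out higher numbers stand for weaker inhibition and lower numbers for stronger inhibition), compound 1 gives 500 nM, the lowest of the two numbers measured so far. Compound 2 `CC(C)CNC(=O)c1cc2ccccc2oc1=O` has isobutyl in place of that cyclohexyl; in this assay compound 2 gives 3270 nM. Among the compounds with values here, the one step known, a 6.5-fold higher number from compound 1 to compound 2 (0.82 log units; beyond the scatter), is the only measured change in the set and concerns the group on the amide-type nitrogen alone.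

Compound 3 `O=C(NC1CCCCC1)c1cc2ccc(OCc3ccccc3)cc2oc1=O` keeps the cyclohexyl amide of compound 1 and differs from it in one place: benzyloxy in place of hydrogen on an aromatic carbon, the entering benzyloxy sitting on an aromatic carbon of the ring that is part of a fused system of two rings, meta to a fused ring and para to a fused ring. Within the data shown here, no measured step touches this position; the step from compound 1 to compound 2 changes a different part of the molecule and gives no guide to size or direction here. With nothing measured on the aromatic carbons, compound 3 is expected to give 400 nM, within 80 nM to 2000 nM, the expected step being a 1.3-fold lower number from compound 1 to compound 3 (0.10 log units; within the scatter), in effect none beyond the scatter, with a wide range on either side.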

Compound 3, half-maximal inhibitory concentration: 64500 nM
Compound 3: middle estimate off by 160-fold (2.21 log units), on the low side; the measured number lies above the stated range.
By their numbers in this assay, from the lowest: compound 1; then compound 2; then compound 3.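

Benzyloxy in place of hydrogen on this aromatic carbon brings a 130-fold higher number from compound 1 to compound 3 (2.11 log units; beyond the scatter) in this assay and so shifts the read-out toward much weaker inhibition, which shows that this position, meta to a fused ring and para to a fused ring, is not indifferent to substitution, at least for a group of this size. Going by these compounds alone, the step is printed as large and the one on the amide-type nitrogen, a 6.5-fold higher number from compound 1 to compound 2 (0.82 log units; beyond the scatter) as the only earlier comparison, as modest, so of the two places changed from compound 1, this aromatic carbon carries the greater change in the number. Nothing available accounts for this loss, and the result alone cannot say which part of the benzyloxy group matters.

Still open, on these data alone, is whether a smaller group on the same carbon, such as methoxy, hydroxy or a chlorine atom, would leave the number close to that of compound 1 or also raise it. Also open, as far as these compounds go, are whether benzyloxy on the other aromatic carbons of the core behaves the same way, and whether the step carries over to the isobutyl amide of compound 2.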